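Stretching the amine chain: from dimethylamino to diethylamino

The source may report more compounds than this note shows. Statements on the series, on what has been measured and on what is new or still open speak of the compounds shown alone.

Of the compounds shown here, three with a shared core have been tested in a functional assay on HepG2 cells (Homo sapiens) for cytotoxicity, read by MTT assay, with a stated time of 72 h; on this read-out higher numbers stand for weaker inhibition and lower numbers for stronger inhibition. Compound 1 `CN(C)CCCOc1c(OCc2ccccc2)cc(O)c2c(=O)cc(-c3ccccc3)oc12` gives 4950 nM. Compound 2 `CN1CCN(CCCOc2c(OCc3ccccc3)cc(O)c3c(=O)cc(-c4ccccc4)oc23)CC1` gives 3110 nM, and compound 3 `CN(C)CCCCOc1c(OCc2ccccc2)cc(O)c2c(=O)cc(-c3ccccc3)oc12` gives 2090 nM, the lowest of the three numbers shown. Among the compounds with values here, the move a 2.4-fold lower number from compound 1 to compound 3 (0.37 log units; beyond the scatter) is the only step that clears the scatter; the moves a 1.6-fold lower number from compound 1 to compound 2 (0.20 log units; within the scatter) and a 1.5-fold lower number from compound 2 to compound 3 (0.17 log units; within the scatter) do not.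

Compound 4 `CCN(CC)CCCCOc1c(OCc2ccccc2)cc(O)c2c(=O)cc(-c3ccccc3)oc12` differs from compound 3 in one place: diethylamino in place of dimethylamino on a saturated chain carbon, four bonds along the chain from an oxygen on an aromatic ring. Within the data shown here, no measured step changes the two groups on the amine nitrogen in this way. The nearest comparisons are the swap of the whole amine in a 1.6-fold lower number from compound 1 to compound 2 (0.20 log units; within the scatter), which stayed within the scatter, and the lengthening of the chain in a 2.4-fold lower number from compound 1 to compound 3 (0.37 log units; beyond the scatter), which was modest. A small change at the amine is therefore expected to move this assay little, if at all, and the expected step of a 1.0-fold lower number from compound 3 to compound 4 (0.02 log units; within the scatter) is taken to lie within the scatter. Compound 4 is accordingly estimated at 2000 nM, with a range from 800 nM to 5000 nM.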

Compound 4, half-maximal inhibitory concentration: 1650 nM
The estimate for compound 4 lay 1.2-fold (0.08 log units) above the measured number; measured number inside the range.
By their numbers in this assay, from the lowest: compounds 4, 3, 2 and 1 (each within the scatter of the next, the first and the last beyond it).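

In this assay, within the data shown here, the first change to the groups on the amine nitrogen gives a 1.3-fold lower number from compound 3 to compound 4 (0.10 log units; within the scatter), so at this place, four bonds along the chain from an oxygen on an aromatic ring, diethylamino and dimethylamino cannot be told apart. Replacing 4-methylpiperazin-1-yl and lengthening the chain gives a 1.9-fold lower number from compound 2 to compound 4 (0.28 log units; within the scatter), which also stays unresolved, whereas a 3.0-fold lower number from compound 1 to compound 4 (0.48 log units; beyond the scatter) is the widest gap among the four compounds, though still modest. No measurement shown explains these numbers.

On these data alone, it remains open whether a ring amine such as morpholine or piperidine on the same chain would differ from diethylamino. A still longer chain carrying diethylamino could also show whether the modest gain seen with chain length continues or fades.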